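This account rests on a few compounds, and the source may have more. Where it says the series, first, only, none or still open, it means among the compounds named here.

Compound 1, `Nc1ccc(NC(=O)c2cn(Cc3c(F)cccc3F)c3ccc(=O)[nH]c3c2=O)cc1`: 104 nM
Compound 2, `N#Cc1ccc(NC(=O)c2cn(Cc3c(F)cccc3F)c3ccc(=O)[nH]c3c2=O)cc1`: 96 nM
Compound 3, `CSc1ccc(NC(=O)c2cn(Cc3c(F)cccc3F)c3ccc(=O)[nH]c3c2=O)cc1`: 86 nM

All three values come from an in vitro assay on Sf21 cells for inhibition of high affinity 3',5'-cyclic-AMP phosphodiesterase 7A (Homo sapiens), read by scintillation proximity assay, with a stated time of 30 min; a higher number here means a weaker inhibitor, a lower number a stronger inhibitor. Compound 2 stands second highest of the three numbers, and its neighbours sit close: the step of a 1.1-fold lower number from compound 1 to compound 2 (0.03 log units; within the scatter) and the step of a 1.1-fold lower number from compound 2 to compound 3 (0.05 log units; within the scatter) are both within the scatter, as is a 1.2-fold lower number from compound 1 to compound 3 (0.08 log units; within the scatter). The unmeasured compound 4, `O=C(Nc1ccc(OC(F)F)cc1)c1cn(Cc2c(F)cccc2F)c2ccc(=O)[nH]c2c1=O`, differs from compound 2 in one place: difluoromethoxy in place of cyano on an aromatic carbon. Every measured step swaps a group at this same spot on the shared core, and none moved the number beyond the scatter. Compound 4 is therefore expected to show no step beyond the scatter, a 1.0-fold lower number from compound 2 to compound 4 (0.00 log units; within the scatter). Compound 4 is estimated at 95 nM, with a range from 45 nM to 200 nM.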

Compound 4, half-maximal inhibitory concentration: 71 nM
Compound 4: middle estimate off by 1.3-fold (0.13 log units), on the high side; low and high end bracket the measured number.
By their numbers in this assay, from the lowest: compounds 4, 3, 2 and 1 (each within the scatter of the next).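

In this assay difluoromethoxy, with four heavy atoms including two fluorines where cyano has two heavy atoms, still leaves the number within the scatter (a 1.4-fold lower number from compound 2 to compound 4 (0.13 log units; within the scatter)). The same holds against the other two groups (a 1.2-fold lower number from compound 3 to compound 4 (0.08 log units; within the scatter)) and (a 1.5-fold lower number from compound 1 to compound 4 (0.17 log units; within the scatter)), the last being the widest step yet at this position. Nothing measured here bears on why these four groups read so alike. From the compounds shown here alone, whether a carboxylic acid or a longer alkyl chain at this spot would also stay within the scatter remains open.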